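A few compounds are considered here, and "the series" means these few. Any claim that something is new, unique, unknown or untested is made for them only; others in the source may bear on it.

Measured compounds:
- compound 1 `O=C(O)C1=Cc2ccccc2OC1(OCc1cc(-c2ccc(F)cc2)no1)C(F)(F)F`: 168000 nM
- compound 2 `CCOC(=O)C1=Cc2ccccc2OC1(OCc1cn(CC(=O)Nc2ccccc2F)nn1)C(F)(F)F`: 33900 nM
- compound 3 `O=C(O)C1=Cc2ccccc2OC1(OCc1cc(-c2ccc3ccccc3c2)no1)C(F)(F)F`: 141000 nM

In a functional assay on DU-145 cells (Homo sapiens) for inhibition, read by MTT assay, with a stated time of 24 h (on this read-out higher numbers stand for weaker inhibition and lower numbers for stronger inhibition), compound 2 gives the lowest number of the three, and both compound 1 and compound 3 stand above it by more than the scatter. Among the measured compounds shown here, the one single-point step measured so far, a 1.2-fold lower number from compound 1 to compound 3 (0.08 log units; within the scatter), exchanges the aryl group on an aromatic carbon of the other five-membered ring and stays within the scatter.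

Compound 4 `CCOC(=O)C1=Cc2ccccc2OC1(OCc1cn(-c2cccc(OC)c2)nn1)C(F)(F)F` differs from compound 2 by 3-methoxyphenyl in place of ((2-fluorophenyl)carbamoyl)methyl on an aromatic nitrogen. For the measured compounds named here, no measured step touches the substituent on the aromatic nitrogen, and none removes the ((2-fluorophenyl)carbamoyl)methyl group, so the only comparison at hand is indirect: the aryl exchange from compound 1 to compound 3 was within the scatter. On that basis the step to compound 4 is expected to be small, with wide uncertainty in both directions. Compound 4 is therefore estimated at 45000 nM in this assay, with a range of 15000 nM to 130000 nM, which means an expected step of a 1.3-fold higher number from compound 2 to compound 4 (0.12 log units; within the scatter).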

Compound 4, half-maximal inhibitory concentration: > 150000 nM
Compound 4: a limit, no number; the forecaster's own chance of this, stated with the estimate: 5%; middle value at least 3.3-fold (0.52 log units) from the limit.
By their numbers in this assay, from the lowest: compound 2; then compounds 3 and 1 (each within the scatter of the next).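

In this assay compound 4 gives a limit and not a number: the limit of > 150000 nM in this assay, at which 1 of the 4 values shown sits.

The substituent on the aromatic nitrogen is therefore not a neutral place for change in this series, as exchanging ((2-fluorophenyl)carbamoyl)methyl for 3-methoxyphenyl gives an at least 4.4-fold higher number from compound 2 to compound 4 (0.64 log units; beyond the scatter). The earlier aryl exchange, a 1.2-fold lower number from compound 1 to compound 3 (0.08 log units; within the scatter), lay within the scatter, but it sits at a different place on a different ring and gave no reading of this position, and the new step has a lower bound only.

The step replaces the whole group, so the amide hydrogen, the carbonyl and the 2-fluorophenyl ring are not separated from one another in what compound 2 retains over compound 4. Going by these compounds, how a plain alkyl chain or an amine on the same aromatic nitrogen would read stays open, as does whether any group there reaches a number below that of compound 2, 33900 nM.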